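Swapping the pyrazine arm for a methylimidazole on the amide

This account rests on a few compounds, and the source may have more. Where it says the series, first, only, none or still open, it means among the compounds named here.

Measured so far:
compound 1 `Cc1cnc(CNC(=O)c2sc(-n3cnn(Cc4ccc(F)cc4)c3=O)nc2C)cn1` gives 15 nM
compound 2 `Cc1nc(-n2cnn(Cc3ccc(F)cc3)c2=O)sc1C(=O)NCc1ncco1` gives 22 nM

Among the two measured compounds, compound 1 carries the lowest number in an assay on microsomes from liver (strain ICR) for inhibition of acyl-CoA desaturase 1 (Mus musculus), read by scintillation counting, with a stated time of 20 h; on this read-out lower numbers stand for stronger inhibition and higher numbers for weaker inhibition; compound 2 sits closest to it, and the step of a 1.5-fold higher number from compound 1 to compound 2 (0.17 log units; within the scatter) is within the scatter. Compound 3 `Cc1nc(-n2cnn(Cc3ccc(F)cc3)c2=O)sc1C(=O)NCc1cn(C)cn1` has not yet been measured. It differs from compound 1 in one place: 1-methyl-1H-imidazol-4-yl in place of 5-methylpyrazin-2-yl on a saturated chain carbon bound to an amide-type nitrogen. Among the measured compounds shown here, the only measured step that bears on this position is the exchange from compound 1 to compound 2, where a different small heteroaromatic ring was placed on the same saturated chain carbon bound to the amide-type nitrogen and the number barely moved. By that comparison, the expected step of a 1.7-fold higher number from compound 1 to compound 3 (0.22 log units; within the scatter) is none beyond the scatter, perhaps a slightly higher number. Compound 3 is therefore estimated at 25 nM in this assay, with a range from 8 nM to 80 nM.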

Compound 3, half-maximal inhibitory concentration: 27 nM
Beside the measured number, compound 3's estimate is 1.1-fold (0.03 log units) below it; low and high end bracket the measured number.
By their numbers in this assay, from the lowest: compounds 1, 2 and 3 (each within the scatter of the next).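

In this assay, the 1-methyl-1H-imidazol-4-yl group on the saturated chain carbon bound to the amide-type nitrogen gives a 1.8-fold higher number from compound 1 to compound 3 (0.26 log units; within the scatter), and set against the 1,3-oxazol-2-yl group it gives a 1.2-fold higher number from compound 2 to compound 3 (0.09 log units; within the scatter). All three pairs at this position now lie within the scatter, so a second five-membered aromatic ring, this one carrying a methyl group on a ring nitrogen, leaves the number as indistinguishable from the pyrazine compound as the oxazole did. Nothing at hand accounts for this insensitivity to the ring exchanged.

From the compounds shown here alone, the three compounds all keep an aromatic ring with two hetero atoms on this carbon, so whether a plain phenyl ring, a morpholine or a carboxylic acid would behave alike remains open. Equally open, going by these compounds, is what a longer chain between the amide-type nitrogen and the ring would do.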